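The source may hold more compounds than are shown below. What is called first, only, known or untested is meant among the compounds shown, and "the series" means these compounds.

Measured compounds:
- compound 1, `CCN(CC1CC1)c1cc(C)nc2c(-c3ccc(Cl)cc3Cl)nn(C)c12`: 4.4 nM
- compound 2, `Cc1cc(N(CC(C)C)CC2CC2)c2c(n1)c(-c1ccc(Cl)cc1Cl)nn2C`: 3.7 nM
- compound 3, `CCCCCN(CC1CC1)c1cc(C)nc2c(-c3ccc(Cl)cc3Cl)nn(C)c12`: 1.5 nM

These three share one core and differ only in the chains on the nitrogen attached to the aromatic ring. In an assay on HEK293 cells for displacement of a labelled ligand from corticotropin-releasing factor receptor 1 (Homo sapiens) (on this read-out lower numbers stand for stronger inhibition and higher numbers for weaker inhibition), compound 3 gives the lowest number of the three: the step of a 2.9-fold lower number from compound 1 to compound 3 (0.47 log units; beyond the scatter) and the step of a 2.5-fold lower number from compound 2 to compound 3 (0.39 log units; beyond the scatter) both lie beyond the scatter, so compound 3 binds the strongest among the measured set. The step of a 1.2-fold lower number from compound 1 to compound 2 (0.08 log units; within the scatter) stays within the scatter.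

Compound 4, `CCCCCN(CCC)c1cc(C)nc2c(-c3ccc(Cl)cc3Cl)nn(C)c12`, has not been measured. It keeps the pentyl chain of compound 3 and changes the other chain: ethyl in place of cyclopropyl on a saturated chain carbon bound to a nitrogen on an aromatic ring. For the measured compounds named here, no measured step touches the cyclopropylmethyl group, so the bearing evidence is indirect. The steps among compounds 1, 2 and 3 show that chain changes on this nitrogen shift this assay at most modestly. A small loss or no change beyond the scatter is therefore expected, as a 1.7-fold higher number from compound 3 to compound 4 (0.22 log units; within the scatter), giving for compound 4 an estimated 2.5 nM within a range from 1 nM to 7 nM.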

Compound 4, inhibition constant: 1.2 nM
For compound 4 the middle estimate is 2.1-fold (0.32 log units) above the measured one, and the stated range covers the measured number.
By their numbers in this assay, from the lowest: compounds 4 and 3 (each within the scatter of the next); then compounds 2 and 1 (each within the scatter of the next).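

In this assay, for the compounds shown here, this is the first change that touches the cyclopropylmethyl group: with the pentyl chain kept, replacing it with propyl gives a step that stays within the scatter (a 1.3-fold lower number from compound 3 to compound 4 (0.10 log units; within the scatter)), so in this pair opening the three-membered ring leaves no measurable mark. The other two steps both lie beyond the scatter, though they are modest (a 3.1-fold lower number from compound 2 to compound 4 (0.49 log units; beyond the scatter); a 3.7-fold lower number from compound 1 to compound 4 (0.56 log units; beyond the scatter)), so the lower numbers seen with the pentyl chain persist once the ring is gone. Nothing at hand explains why these chains give these numbers.

From the compounds shown here alone, it remains open whether a longer chain such as heptyl, or an amine or a hydroxyl group on the pentyl chain, would keep numbers this low. Also open, going by these compounds, is what changing the pentyl chain alone would do with the propyl chain kept.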